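Swapping a methylsulfonyl end for a hydroxy end

The compounds below may be only part of what the source reports. "The series", "measured", "known", "first", "only" and "open" are said of these compounds alone.

Measured in an ADME assay on microsomes from liver (Homo sapiens) for metabolic stability (on this read-out higher numbers stand for a longer-lived compound and lower numbers for a shorter-lived compound), so far:
- compound 1 `CC#C[C@@H](Cc1nnn[nH]1)c1ccc(OCc2ccc3scc(-c4cccnc4C)c3c2)cc1` gives < 0.0667 h (a limit of the assay, not a number)
- compound 2 `CC#C[C@@H](Cc1nnn[nH]1)c1ccc(OCc2ccc3scc(-c4ccc(OCCCS(C)(=O)=O)cc4C)c3c2)cc1` gives 1.28 h

For the measured compounds named here, compound 2 holds the only true number so far (1.28 h) and so serves as the starting point. In compound 3 `CC#C[C@@H](Cc1nnn[nH]1)c1ccc(OCc2ccc3scc(-c4ccc(OCCC(C)(C)O)cc4C)c3c2)cc1` a single part changes, on a saturated chain carbon, two bonds along the chain from an oxygen on an aromatic ring (1-hydroxy-1-methylethyl in place of (methylsulfonyl)methyl on a saturated chain carbon, two bonds along the chain from an oxygen on an aromatic ring). Read over the whole side chain, 3-(methylsulfonyl)propoxy becomes 3-hydroxy-3-methylbutoxy, and the rest of the molecule stays the same. Going by the values given here, no measured pair shows this swap, so the expectation rests on compound 2 alone. The expected step of a 1.6-fold lower number from compound 2 to compound 3 (0.20 log units; within the scatter) is small, pointing to a slightly shorter half-life and staying inside the usual scatter of this assay when repeated. The estimate for compound 3 is 0.8 h (0.3 h to 2 h).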

Compound 3, half-life: 0.95 h
The estimate for compound 3 lay 1.2-fold (0.07 log units) below the measured number, and the stated range covers the measured number.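

In this assay, replacing the 3-(methylsulfonyl)propoxy side chain with 3-hydroxy-3-methylbutoxy gives a 1.3-fold lower number from compound 2 to compound 3 (0.13 log units; within the scatter), so this read-out does not separate the two ends. At this place, on a saturated chain carbon, two bonds along the chain from an oxygen on an aromatic ring, the methylsulfonyl end is therefore not required for a half-life of this size: the hydroxy end, with a hydrogen-bond donor the other lacks, serves equally well here. Nothing shown gives a reason for this result.

As far as these compounds go, this rests on a single pair, so it remains open whether it holds for other ends, such as an amine, a carboxylic acid or a longer chain. From the compounds shown here alone, it also remains open whether the same swap would behave alike on a different core.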